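A Pentafluorophenyl Swap Awaiting Its Growth Inhibition Value

The source may hold more compounds than are shown below. What is called first, only, known or untested is meant among the compounds shown, and "the series" means these compounds.

Measured in a functional assay on DU-145 cells (Homo sapiens) for inhibition, read by trypan blue exclusion, with a stated time of 96 h; on this read-out higher numbers stand for weaker inhibition of growth and lower numbers for stronger inhibition of growth:
- compound 1 (`O=C(/C(=C\c1ccc(O)c([N+](=O)[O-])c1)SCc1ccc(Br)cc1)c1c(F)c(F)c(F)c(F)c1F`): 10000 nM
- compound 2 (`O=C(/C(=C\c1ccc(O)c([N+](=O)[O-])c1)S(=O)(=O)Cc1ccc(Br)cc1)c1c(F)c(F)c(F)c(F)c1F`): 50000 nM

Compound 1 holds the lower of these two numbers. Compound 3 (`O=C(/C(=C\c1ccc(O)c([N+](=O)[O-])c1)SCc1ccc(Br)cc1)c1ccc([N+](=O)[O-])cc1`) keeps the core of compound 1 but carries 4-nitrophenyl in place of 2,3,4,5,6-pentafluorophenyl on a carbonyl carbon. Going by the values given here, the only measured step is a 5.0-fold higher number from compound 1 to compound 2 (0.70 log units; beyond the scatter), which is modest and beyond the scatter. That step puts (4-bromobenzyl)sulfonyl in place of (4-bromobenzyl)sulfanyl and leaves the group on the carbonyl carbon untouched. Among the compounds with values here, no measured step therefore bears directly on this swap, and no direction is favoured in this assay, though a step of similar modest size either way remains possible. The expected outcome is no change at the digits printed from compound 1 to compound 3 (within the scatter). For compound 3 the estimated value is 10000 nM, with an expected range from 3000 nM to 35000 nM.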

Compound 3, concentration for 50% growth inhibition: 10000 nM
Compound 3: the middle estimate sits on the measured number at the digits printed, and the stated range covers the measured number.
By their numbers in this assay, from the lowest: compounds 1 and 3 (each within the scatter of the next); then compound 2.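

In this assay, going by these compounds alone, the exchange on the carbonyl carbon of 2,3,4,5,6-pentafluorophenyl for 4-nitrophenyl gave no change at the digits printed from compound 1 to compound 3 (within the scatter), the first reading at this position, since the earlier step changed only the sulfur-linked side of the molecule. Within the compounds shown, the number therefore held across two different aryl groups: the leaving group has 11 heavy atoms and no hydrogen-bond acceptors, and the entering group has 9 heavy atoms and 2 hydrogen-bond acceptors. Nothing available explains why the number held.

From the compounds shown here alone, it remains open whether the same holds for other groups on the carbonyl carbon, such as unsubstituted phenyl or a phenyl ring carrying an amine or a carboxylic acid. Going by these compounds, it is also open whether the step from sulfanyl to sulfonyl would be of similar size with 4-nitrophenyl on the carbonyl carbon.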